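The source may report more compounds than this note shows. Statements on the series, on what has been measured and on what is new or still open speak of the compounds shown alone.

Measured compounds in a functional assay on EL4 cells (Mus musculus) for inhibition, tested at 100 uM; on this read-out higher numbers stand for more inhibition at the one concentration tested (going by the name of the read-out) and lower numbers for less inhibition:
compound 1 `CCNc1nccc2c1ncn2C1O[C@H](CO)[C@@H](O)[C@H]1O`, value 8%.
compound 2 `OC[C@H]1OC(n2cnc3c(S)nccc32)[C@H](O)[C@@H]1O`, value < 5%, which is a limit of this assay rather than a number.

Compound 2 therefore stands only at the limit of < 5% in this assay, at which 1 of the 2 values shown sits, with no number of its own. Among the measured compounds shown here, the one measured step, a number at least 3 percentage points lower from compound 1 to compound 2 (that floor lies within the scatter), runs downward, but its floor lies within the scatter, so the step carries little weight.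

Compound 3 `OC[C@H]1OC(n2cnc3c(Cl)nccc32)[C@H](O)[C@@H]1O` is not yet measured. It differs from compound 2 by chloro in place of sulfanyl on an aromatic carbon. For the measured compounds named here, the only measured step bearing on this position is the one from compound 1 to compound 2, and it gives no indication of a step beyond the scatter; no step is expected from compound 2 to compound 3 in this assay, a step that the limit leaves unreadable from compound 2 to compound 3. Compound 3 is expected to give 3% in this assay, in the range 0% to 10%, most likely again reported only as a limit.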

Compound 3, a percentage reported as inhibition, at one concentration (the size of the read-out at that concentration, not a potency): < 5%
Compound 3: no number, only a limit; the forecaster's own chance of this, stated with the estimate: 65%; the middle value lies beyond the limit too.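

In this assay compound 3 gives < 5%, which is a limit and not a number. With chloro in place of ethylamino on this aromatic carbon next to the ring nitrogen, the reading is a number at least 3 percentage points lower from compound 1 to compound 3 (that floor lies within the scatter), so this second replacement of ethylamino also shows no step beyond the scatter. The step between sulfanyl and chloro cannot be read, since compound 2 and compound 3 both sit at a limit, and the series now clusters there: the limit of < 5% in this assay, at which 2 of the 3 values shown sit.

From the compounds shown here alone, whether any group on this carbon can raise the inhibition in this assay beyond the scatter remains open. A longer chain such as butylamino, or a primary amine or methoxy group, would show whether this position responds at all on the shared core.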